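A few compounds are considered here, and "the series" means these few. Any claim that something is new, unique, unknown or untested is made for them only; others in the source may bear on it.

Measured so far:
- compound 1, `Cc1coc(-c2nn(Cc3ccccc3F)c3ncccc23)n1`: 1200 nM
- compound 2, `CC(C)(C)c1cnc(-c2nn(Cc3ccccc3F)c3ncccc23)nc1N`: 709000 nM

Both were run in a functional assay (aorta) with Oryctolagus cuniculus as the target; a higher number here means a weaker inhibitor, a lower number a stronger inhibitor. Compound 1 gives 1200 nM; compound 2 gives 709000 nM and thus stands at the higher of the two numbers, a gap to compound 1 that lies far beyond the usual scatter. The two differ in more than one place, so nothing is said here about which part of that difference carries the gap.

Compound 3, `NCc1cnc(-c2nn(Cc3ccccc3F)c3ncccc23)nc1N`, is not yet measured. It differs from compound 2 in one place: aminomethyl in place of tert-butyl on an aromatic carbon. Among the compounds with values here, no measured pair isolates such a change, so no step size can be drawn from the data. The expectation is a step from compound 2 to compound 3 of a 1.4-fold lower number from compound 2 to compound 3 (0.15 log units; within the scatter), no larger than the scatter in either direction. Compound 3 is therefore estimated at 500000 nM, within 100000 nM to 3000000 nM.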

Compound 3, half-maximal inhibitory concentration: 1400000 nM
For compound 3 the middle estimate is 2.8-fold (0.45 log units) below the measured one; the measured number falls inside the stated range.
By their numbers in this assay, from the lowest: compound 1; then compounds 2 and 3 (each within the scatter of the next).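

Aminomethyl in place of tert-butyl on an aromatic carbon, ortho to an amino group, gives in this assay the first one-place step of the series: a 2.0-fold higher number from compound 2 to compound 3 (0.30 log units; within the scatter). At this position, then, exchanging a four-carbon group with no hydrogen-bond donors or acceptors for a smaller group that carries both leaves compound 2 and compound 3 indistinguishable in this read-out. Nothing measured here accounts for this outcome.

From the compounds shown here alone, it remains open whether another group at this position, such as a carboxylic acid, a dimethylamine or a longer alkyl chain, would give a step beyond the scatter. Within the data shown here, it also remains open which structural part separates compound 1 from compound 2 and compound 3, as no one-place step links them.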